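Swapping a ring for a branched chain on a sulfonamide

A few compounds are considered here, and "the series" means these few. Any claim that something is new, unique, unknown or untested is made for them only; others in the source may bear on it.

Of the compounds shown here, two of a shared core have been tested in a functional assay on K562 cells (Homo sapiens) for antiproliferative activity, read by CCK-8 assay, with a stated time of 72 h; on this read-out higher numbers stand for weaker inhibition of growth and lower numbers for stronger inhibition of growth. Compound 1 `CC[C@@H]1C(=O)N(C)c2cnc(Nc3ccc(S(=O)(=O)NC4CCCC4)cc3)nc2N1C1CCCC1` gives 872 nM in this assay. Compound 2 `CCC1C(=O)N(C)c2cnc(Nc3ccc(S(=O)(=O)NC)cc3)nc2N1c1ccn(C)n1` differs from compound 1 in several places. In this assay compound 2 gives 2890 nM. Of these two numbers, compound 1 has the lower one, and the gap to compound 2 lies beyond the usual scatter of repeated measurements.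

Compound 3 `CC[C@@H]1C(=O)N(C)c2cnc(Nc3ccc(S(=O)(=O)NCC(C)C)cc3)nc2N1C1CCCC1` has not yet been measured. It differs from compound 1 in a single place: isobutyl in place of cyclopentyl on a sulfonamide nitrogen. The rest of the molecule is unchanged. Among the compounds with values here, no measured pair of compounds shows this particular change, so there is no direct precedent among the numbers at hand.

With only that to go on, the step from compound 1 to compound 3 is expected to be small, and a 1.3-fold higher number from compound 1 to compound 3 (0.10 log units; within the scatter) is the estimated change, which could fall on either side of no change at all. Compound 3 is therefore expected to give about 1100 nM in this assay, with a plausible range from 400 nM to 3000 nM.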

Compound 3, concentration for 50% growth inhibition: 705 nM
The estimate for compound 3 lay 1.6-fold (0.19 log units) above the measured number; measured number inside the range.
By their numbers in this assay, from the lowest: compounds 3 and 1 (each within the scatter of the next); then compound 2.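

In this assay, within the data shown here, this is the first direct test of a change at the sulfonamide nitrogen, and it gives a 1.2-fold lower number from compound 1 to compound 3 (0.09 log units; within the scatter) when isobutyl replaces cyclopentyl. The two compounds therefore cannot be told apart on this read-out, which shows that, with the rest of compound 1 unchanged, a ring on this nitrogen is not required to keep growth inhibition in this range: an open, branched chain made only of carbon serves as well. Nothing available explains why these two groups read alike.

Compound 2 carries a methyl on the same nitrogen but also differs from compound 1 elsewhere, so it cannot show what the methyl group does on its own. Going by these compounds, it remains open whether a group of a different kind on this nitrogen, such as a chain ending in an amine or a carboxylic acid, or a longer straight carbon chain, would fit as well as cyclopentyl and isobutyl, and whether this swap would give the same result on a different core.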